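A few compounds are considered here, and "the series" means these few. Any claim that something is new, unique, unknown or untested is made for them only; others in the source may bear on it.

Measured in an ADME assay on microsomes from liver (Rattus norvegicus) for metabolic stability, read by mass spectrometry, using NADPH, with a stated time of 10 min; on this read-out lower numbers stand for a less stable compound and higher numbers for a more stable compound:

Compound 1 `CCCCc1[nH]c(=O)c(-c2nnc(Cc3ccccc3)o2)c(O)c1-c1c(OC)cccc1OC`: 53%
Compound 2 `COc1cccc(OC)c1-c1c(C2CCCC2)[nH]c(=O)c(-c2nnc(Cc3ccc(Cl)cc3)o2)c1O`: 66%
Compound 3 `CCCCc1[nH]c(=O)c(-c2nc(Cc3ccccc3)no2)c(O)c1-c1c(OC)cccc1OC`: 54%

Of these three, compound 2 stands highest at 66%, and its gaps to compound 1 and compound 3 both lie beyond the usual scatter. Compound 1 and compound 3 sit within the scatter of each other.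

The next compound to be tested is compound 4 `CCCCc1[nH]c(=O)c(-c2nnc(Cc3ccc(Cl)cc3)o2)c(O)c1-c1c(OC)cccc1OC`, which has butyl in place of cyclopentyl on an aromatic carbon. Going by the values given here, no pair of measured compounds differs in this one place alone, so the size of the step in this assay cannot be read directly. Among the compounds with values here, the only guide is indirect: differing from compound 4 elsewhere but also carrying butyl, compound 1 gives 53%. A modest fall is therefore expected, possibly no larger than the scatter, and the estimated step is a number 8 percentage points lower from compound 2 to compound 4 (within the scatter). For compound 4 the expected value is 58%, with an estimated range from 45% to 70%.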

Compound 4, percent of the compound remaining: 22%
Compound 4: the middle estimate sits 36 percentage points above what was measured; measured number outside the range, below it.
By their numbers in this assay, from the lowest: compound 4; then compounds 1 and 3 (each within the scatter of the next); then compound 2.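

Read as a single change in this assay, butyl in place of cyclopentyl on this aromatic carbon, next to the ring nitrogen, is a large step (a number 44 percentage points lower from compound 2 to compound 4 (beyond the scatter)), so this position strongly affects the read-out. With butyl held fixed, chloro in place of hydrogen on an aromatic carbon is also a large step (a number 31 percentage points lower from compound 1 to compound 4 (beyond the scatter)), so the chloro change lowers the number in the butyl setting. The data give no explanation for either step.

Whether the chloro change would have a similar effect alongside cyclopentyl cannot be read from these compounds. Going by these compounds, it also remains open where other groups at this position, such as isopropyl, cyclohexyl or a longer chain, would fall relative to butyl and cyclopentyl.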